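The source may hold more compounds than are shown below. What is called first, only, known or untested is meant among the compounds shown, and "the series" means these compounds.

Measured so far in an in vitro ADME assay on microsomes from liver (Homo sapiens) for pharmacokinetics, read by LC-MS, with a stated time of 10 min, tested at 1 uM; a higher number here means faster removal of the compound, a lower number slower removal:

- compound 1, `Cc1ccc(NC(=O)[C@H]2CN(C)C[C@@H]2c2ccc(/C=C/C(=O)Nc3ccccc3N)cc2)cc1`, gives 15 mL/min/kg
- compound 2, `CN1C[C@H](C(=O)Nc2ccc(Br)cc2)[C@@H](c2ccc(/C=C/C(=O)Nc3ccccc3N)cc2)C1`, gives 3 mL/min/kg
- compound 3, `Cc1cc(NC(=O)[C@H]2CN(C)C[C@@H]2c2ccc(/C=C/C(=O)Nc3ccccc3N)cc2)ccc1F`, gives 15 mL/min/kg

These three share one core and differ only in the group carried on an amide-type nitrogen. Compound 1 and compound 3 differ by 4-fluoro-3-methylphenyl in place of 4-methylphenyl on an amide-type nitrogen, and no change at the digits printed from compound 1 to compound 3 (within the scatter). The change bromo in place of methyl on an aromatic carbon gave a 5.0-fold lower number from compound 1 to compound 2 (0.70 log units; beyond the scatter).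

Compound 4, `CN1C[C@H](C(=O)Nc2ccc(F)c(Br)c2)[C@@H](c2ccc(/C=C/C(=O)Nc3ccccc3N)cc2)C1`, has not yet been measured. It is made from compound 3 by bromo in place of methyl on an aromatic carbon. Within the data shown here, this is the same kind of change as the one from compound 1 to compound 2, not the same: in the earlier pair the new group sits para to a large group, whereas in compound 4 it sits ortho to a fluoro group and meta to a large group. Resting on the step from compound 1 to compound 2, compound 4 is expected to show a 3.0-fold lower number from compound 3 to compound 4 (0.48 log units; beyond the scatter). With that reasoning, compound 4 is estimated at 5 mL/min/kg, with a likely range from 2 mL/min/kg to 14 mL/min/kg.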

Compound 4, clearance: 15 mL/min/kg
For compound 4 the middle estimate is 3.0-fold (0.48 log units) below the measured one, outside the stated range (above it).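

Putting bromo in place of methyl on an aromatic carbon gave, in this assay, no change at the digits printed from compound 3 to compound 4 (within the scatter), so this change did not carry over at the same size from one core to the other: the same change on two cores in this assay, a 5.0-fold lower number (0.70 log units; beyond the scatter) from compound 1 to compound 2 and no change at the digits printed (within the scatter) from compound 3 to compound 4, 5.0-fold (0.70 log units) apart, beyond the scatter of two such steps. Compared with the other two compounds, there is a 5.0-fold higher number from compound 2 to compound 4 (0.70 log units; beyond the scatter) and no change at the digits printed from compound 1 to compound 4 (within the scatter), so a bromo on this ring does not bring a low number by itself. What this does not show is why the two steps differ: compound 2 and compound 4 differ both in the fluoro group and in where the bromo sits, and one pair on each core cannot separate those two differences or show how often such a gap would appear.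

Still open, going by these compounds, is how a 3-bromophenyl or a 4-chlorophenyl group on the amide-type nitrogen would compare, which could help separate the part played by the fluoro group from that of the bromo's position. Also open, on these data alone, is whether either step would hold on a further core.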